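The compounds below may be only part of what the source reports. "The series", "measured", "known", "first", "only" and "open" are said of these compounds alone.

Of the compounds shown here, three sharing one core have been measured in a functional assay on OCI-Ly3 cells (Homo sapiens) for inhibition, read by CellTiter-Glo, with stated times of 48 h and 96 h; a higher number here means a weaker inhibitor of growth, a lower number a stronger inhibitor of growth.

- Compound 1 (`CC(C)[C@H](NC(=O)c1cccc(Br)c1)C(=O)N1CCC[C@H]1C(=O)N[C@@H](CCCNC(=N)N)C(=O)CF`) gives 530 nM
- Compound 2 (`CC(C)[C@H](NC(=O)c1ccc(C(F)(F)F)cc1)C(=O)N1CCC[C@H]1C(=O)N[C@@H](CCCNC(=N)N)C(=O)CF`) gives 120 nM
- Compound 3 (`CC(C)[C@H](NC(=O)Nc1ccccc1)C(=O)N1CCC[C@H]1C(=O)N[C@@H](CCCNC(=N)N)C(=O)CF`) gives 1520 nM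

Compound 3 has the highest of these three numbers, making it the weakest growth inhibitor of the set in this assay. The next compound to be tested is compound 4 (`CC(C)[C@H](NC(=O)Nc1ccc(Cl)cc1)C(=O)N1CCC[C@H]1C(=O)N[C@@H](CCCNC(=N)N)C(=O)CF`), which has chloro in place of hydrogen on an aromatic carbon of compound 3: chloro in place of hydrogen on an aromatic carbon.

For the measured compounds named here, no measured step makes this exact change. Going by the values given here, two steps bear on it only indirectly, since each replaces a substituted aryl group on the carbonyl carbon with anilino. One is modest, a 2.9-fold higher number from compound 1 to compound 3 (0.46 log units; beyond the scatter), and the other is large, a 13-fold higher number from compound 2 to compound 3 (1.10 log units; beyond the scatter). Both substituted compounds therefore sit at lower numbers than compound 3, although their link to the ring also differs. Compound 2, which carries 4-(trifluoromethyl)phenyl, shows how low a number a ring with a group in that place can reach, at 120 nM. A single chloro is expected to recover only part of that gap, so a modest move to a lower number is expected, estimated as a 3.0-fold lower number from compound 3 to compound 4 (0.48 log units; beyond the scatter). For compound 4, the estimated value is 500 nM, with an expected range of 150 nM to 1600 nM.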

Compound 4, concentration for 50% growth inhibition: 780 nM
For compound 4 the middle estimate is 1.6-fold (0.19 log units) below the measured one; measured number inside the range.
By their numbers in this assay, from the lowest: compound 2; then compounds 1, 4 and 3 (each within the scatter of the next, the first and the last beyond it).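

In this assay, chloro on this aromatic carbon, para to a large group, gives a 1.9-fold lower number from compound 3 to compound 4 (0.29 log units; within the scatter), so this single atom does not separate compound 4 from compound 3. Compound 4 also cannot be told apart from compound 1, with a 1.5-fold higher number from compound 1 to compound 4 (0.17 log units; within the scatter), whereas compound 2 stays clearly apart, with a 6.5-fold higher number from compound 2 to compound 4 (0.81 log units; beyond the scatter), and so the large distance to compound 2 remains with chloro in place. No measurement shown here gives a reason for any of these steps.

From the compounds shown here alone, it remains open whether another group on this same aromatic carbon of compound 3, such as trifluoromethyl, a nitrile, an amine or a carboxylic acid, would move the number beyond the scatter. Also open, going by these compounds, is how 4-chlorophenyl would read when attached directly to the carbonyl carbon, as the aryl groups of compound 1 and compound 2 are, which would show the effect of the amino link with the ring held the same.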